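The source may hold more compounds than are shown below. What is called first, only, known or untested is meant among the compounds shown, and "the series" means these compounds.

Compound 1 `O=C(COc1ccc(C(=O)/C=C/c2ccc(Cl)cc2Cl)cc1)N[C@H]1CCOC1=O` was run in a functional assay on MGC-803 cells (Homo sapiens) for antiproliferative activity, read by MTT assay, with a stated time of 72 h (a higher number here means a weaker inhibitor, a lower number a stronger inhibitor), where compound 1 gives 26500 nM. Two other members of the series were tested in the same way. Compound 2 `Cc1ccc(C(C)C)c(OCCSC(=S)N[C@H]2CCOC2=O)c1` gives 43400 nM in this assay, a number that sits within the scatter of the value of compound 1, so no order between the two can be read. Compound 3 `O=C1OCC[C@@H]1NC(=S)SCCOc1ccc([N+](=O)[O-])cc1` returns only a limit of the assay, > 100000 nM, and not a number; this is the limit of > 100000 nM in this assay, at which 1 of the 3 values shown sits. On the numbers shown, compound 1 thus stands level with compound 2, with compound 3 out of reach.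

Compound 4 `CC(C)c1ccc(/C=C/C(=O)c2ccc(OCC(=O)N[C@H]3CCOC3=O)cc2)cc1` is the untested analogue, differing from compound 1 by 4-isopropylphenyl in place of 2,4-dichlorophenyl on a double-bonded chain carbon bound to a double-bonded chain carbon. Going by the values given here, no two measured compounds differ in one place, so there is no measured step to lean on. For the step from compound 1 to compound 4 no shift beyond the scatter is expected in either direction, the estimated step being a 1.1-fold higher number from compound 1 to compound 4 (0.05 log units; within the scatter). Compound 4 is therefore expected to give about 30000 nM in this assay, within a range from 10000 nM to 90000 nM.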

Compound 4, half-maximal inhibitory concentration: 16800 nM
Compound 4: middle estimate off by 1.8-fold (0.25 log units), on the high side; low and high end bracket the measured number.
By their numbers in this assay, from the lowest: compounds 4, 1 and 2 (each within the scatter of the next, the first and the last beyond it). At a limit, above all of these: compound 3.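

In this assay the series now has its first one-place step, a 1.6-fold lower number from compound 1 to compound 4 (0.20 log units; within the scatter) for 4-isopropylphenyl in place of 2,4-dichlorophenyl on a double-bonded chain carbon bound to a double-bonded chain carbon. At this position, then, an all-carbon group of 9 heavy atoms and a chlorine-bearing group of 8 cannot be told apart, so for this pair the chlorines are not needed to keep the number in this range. No measured property of either group bears on this step.

On these data alone, whether an amine or a carboxylic acid on the phenyl ring at this position would move the number beyond the scatter stays open. Also open, as far as these compounds go, is what a longer chain in place of the amide-bearing linker in the core of compound 1 would do.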